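The source may hold more compounds than are shown below. What is called first, only, known or untested is meant among the compounds shown, and "the series" means these compounds.

In a functional assay on SW-620 cells (Homo sapiens) for antiproliferative activity, read by MTT assay, with a stated time of 3 days (on this read-out higher numbers stand for weaker inhibition and lower numbers for stronger inhibition), compound 2 `O=C1c2ccccc2C(=O)N1C/C=C\Cn1cc(C#Cc2ccc(Br)cc2)c(=O)[nH]c1=O` gives only a limit, > 100000 nM, and so stands at the limit of > 100000 nM in this assay, at which 1 of the 3 values shown sits. Two related compounds give numbers: compound 1 `CCCCCCCCC#Cc1cn(C/C=C\CN2C(=O)c3ccccc3C2=O)c(=O)[nH]c1=O` gives 67000 nM, and compound 3 `CCCCCCC#Cc1cn(C/C=C/CN2C(=O)c3ccccc3C2=O)c(=O)[nH]c1=O` gives 32000 nM. Compound 4 `CCCCC#Cc1cn(C/C=C\CN2C(=O)c3ccccc3C2=O)c(=O)[nH]c1=O` differs from compound 2 by butyl in place of 4-bromophenyl on a triple-bonded carbon, with butyl in place of 4-bromophenyl on a triple-bonded carbon. The closest measured step is an at least 1.4-fold higher number from compound 1 to compound 2 (0.17 log units; that floor lies within the scatter), with 4-bromophenyl replacing the longer octyl. Based on that step, only a small move to a lower number is expected in this assay, possibly no larger than the scatter. The estimated change is an at least 1.6-fold lower number from compound 2 to compound 4 (0.22 log units; that floor lies within the scatter). For compound 4, the expected value is 60000 nM, with an estimated range of 25000 nM to 100000 nM.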

Compound 4, half-maximal inhibitory concentration: 82000 nM
Compound 4: middle estimate off by 1.4-fold (0.14 log units), on the low side; the measured number falls inside the stated range.
By their numbers in this assay, from the lowest: compound 3; then compounds 1 and 4 (each within the scatter of the next). At a limit, above all of these: compound 2.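

In this assay, among the compounds shown here, butyl and octyl on the triple-bonded carbon are not told apart, which the earlier compounds did not show: a 1.2-fold higher number from compound 1 to compound 4 (0.09 log units; within the scatter). Butyl in place of 4-bromophenyl gives an at least 1.2-fold lower number from compound 2 to compound 4 (0.08 log units; that floor lies within the scatter), so the compounds shown do not yet separate the aryl group from the chains. Compound 2 is only a limit, and the step from it is only a floor: the limit of > 100000 nM in this assay, at which 1 of the 4 values shown sits.

Going by these compounds, whether an amine or a carboxylic acid on the chain at this triple-bonded carbon would move the number beyond the scatter stays open.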